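The source may hold more compounds than are shown below. What is called first, only, known or untested is meant among the compounds shown, and "the series" means these compounds.

Compound 1 `O=c1c(-c2ccccc2)coc2cc(OC/C(=N/O)c3ccc(F)cc3)ccc12` and compound 2 `COc1ccc(/C(COc2ccc3c(=O)c(-c4ccccc4)coc3c2)=N\O)cc1` share one core, and compound 3 `CO/N=C(/COc1c(-c2ccccc2)oc2ccccc2c1=O)c1ccc(F)cc1` and compound 4 `CO/N=C(/COc1c(-c2ccccc2)oc2ccccc2c1=O)c1ccc(OC)cc1` share another; the difference between the two cores is not broken down here. In a functional assay on SK-HEP1 cells (Homo sapiens) for antiproliferative activity (a higher number here means a weaker inhibitor of growth, a lower number a stronger inhibitor of growth), compound 1 gives 6610000 nM, and compound 2 gives 5510000 nM. The change from compound 1 to compound 2 is methoxy in place of fluoro on an aromatic carbon, and this step made a 1.2-fold lower number from compound 1 to compound 2 (0.08 log units; within the scatter). In this assay compound 3 gives 13000000 nM, and the gap between compound 3 and compound 2 is beyond the scatter, while the gap between compound 3 and compound 1 is within it. Compound 4 has not yet been measured. The change from compound 3 to compound 4 is methoxy in place of fluoro on an aromatic carbon, the same change as that from compound 1 to compound 2, made at the same place. Within the data shown here, for compound 4 a step of about a 1.2-fold lower number from compound 3 to compound 4 (0.07 log units; within the scatter) is expected, because a 1.2-fold lower number from compound 1 to compound 2 (0.08 log units; within the scatter) is the only earlier instance of this change. The estimate for compound 4 in this assay is therefore 11000000 nM, expected to fall between 5000000 nM and 25000000 nM.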

Compound 4, concentration for 50% growth inhibition: 11000000 nM
Estimate against measurement, compound 4: no gap at the digits printed, and the stated range covers the measured number.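

In this assay, replacing fluoro with methoxy, which turns 4-fluorophenyl into 4-methoxyphenyl, gives a 1.2-fold lower number from compound 3 to compound 4 (0.07 log units; within the scatter), so on this second core the swap again stays within the scatter. The two cores agree closely on this swap: the same change on two cores in this assay, a 1.2-fold lower number (0.08 log units; within the scatter) from compound 1 to compound 2 and a 1.2-fold lower number (0.07 log units; within the scatter) from compound 3 to compound 4, 1.0-fold (0.01 log units) apart, within the scatter of two such steps

Among these compounds, this shows that, on these two cores, the swap has no effect large enough to stand out from the scatter, but it rests on only one pair of compounds per core, and it cannot show whether a swap with a larger effect would carry over in the same way, or whether this one would hold on any further core.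

On these data alone, only fluoro and methoxy appear at this place, so it remains open how an amine, a carboxylic acid or a longer alkoxy chain there would behave on either core. The compounds also leave open which part of the difference between the two cores matters for growth inhibition, since no pair shown crosses from one core to the other with a single change.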